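The source may report more compounds than this note shows. Statements on the series, on what has been measured and on what is new or still open speak of the compounds shown alone.

Measured compounds:
compound 1 `Cc1ccc2cc(CN(Cc3ccc(C(C)C)cc3)Cc3ccccc3F)c(=O)[nH]c2c1`: > 33000 nM
compound 2 `Cc1ccc2[nH]c(=O)c(CN(Cc3ccc(OC(C)C)cc3)Cc3ccc(C(C)(C)C)cc3)cc2c1`: > 5000 nM

Both results in a toxicity assay on MDCK cells (Canis lupus familiaris) for cytotoxicity, read by crystal violet staining, with a stated time of 48 h (on this read-out higher numbers stand for lower toxicity in this test and lower numbers for higher toxicity in this test), are limits of the assay rather than numbers. For compound 1 the result in this assay is a limit, > 33000 nM. For compound 2 the result in this assay is likewise a limit, > 5000 nM. No step between measured compounds can be drawn; compound 2 stands at the limit of > 5000 nM in this assay, at which 1 of the 2 values shown sits, with one further limit shown. Compound 3 `Cc1ccc2[nH]c(=O)c(CN(Cc3ccc(C(C)(C)C)cc3)C(C)c3ccc(OC(F)F)cc3)cc2c1` differs from compound 2 by 1-(4-(difluoromethoxy)phenyl)ethyl in place of 4-isopropoxybenzyl on an amine nitrogen. With only limits known, no step beyond the scatter is expected, and the step from compound 2 to compound 3 is estimated as a step that the limit leaves unreadable from compound 2 to compound 3. Compound 3 is expected at 20000 nM in this assay, quite possibly reported again as a limit.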

Compound 3, half-maximal cytotoxic concentration: > 5000 nM
Compound 3: a limit, no number (the forecaster's own chance of this, stated with the estimate: 75%); the middle value is on the limit's open side.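

No step can be read from compound 2 to compound 3, as both results are limits. The compounds shown leave open the concentration at which any of them reaches half-maximal cytotoxicity in this assay.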